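The source may report more compounds than this note shows. Statements on the series, on what has been measured and on what is new or still open speak of the compounds shown alone.

Measured compounds:
Compound 1, `COc1ccc(-c2nc(N3CCNCC3)nc3ccccc23)c(OC)c1`: 3.98 ug/mL
Compound 2, `Cn1cc(-c2nc(N3CCNCC3)nc3ccccc23)c2ccccc21`: 16 ug/mL
Compound 3, `CN1CCN(c2nc(-n3ccc4ccccc43)c3ccccc3n2)CC1`: 7.27 ug/mL

Of the compounds shown here, three sharing a common core have been tested in an ADME assay on J774.A1 cells (Mus musculus) for cytotoxicity; a lower number here means that less compound is tolerated, a higher number that more compound is tolerated. Compound 3 stands second highest of the three numbers. Its nearest neighbour is compound 1, whose number is lower by an amount that falls within the usual scatter, so the two cannot be told apart on this evidence. Compound 2 lies furthest from compound 3, with a higher number, and that gap does exceed the scatter.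

The next compound to be examined is compound 4, `c1ccc(N2CCN(c3nc(-n4ccc5ccccc54)c4ccccc4n3)CC2)nc1`. It differs from compound 3 in a single place: pyridin-2-yl in place of methyl on an amine nitrogen in a ring. No comparison between two measured compounds that differ in only one place is available here, so the size of the step has to be judged from the change itself. Because compound 3 sits at 7.27 ug/mL, in the middle of the measured range, a step of either sign is possible, and neither of the other two compounds offers a parallel change; she expects nothing beyond the scatter, with the step from compound 3 to compound 4 estimated as a 1.2-fold lower number from compound 3 to compound 4 (0.08 log units; within the scatter). For compound 4 in this assay the estimated value is 6 ug/mL, with a plausible range from 2.5 ug/mL to 15 ug/mL.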

Compound 4, half-maximal cytotoxic concentration: 1.35 ug/mL
Compound 4: middle estimate off by 4.4-fold (0.65 log units), on the high side, outside the stated range (below it).
By their numbers in this assay, from the lowest: compound 4; then compounds 1 and 3 (each within the scatter of the next); then compound 2.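

In this assay, among the compounds shown here, the change from methyl to pyridin-2-yl on the amine nitrogen in the ring gives the first comparison of compounds differing in one place, and it lies beyond the scatter: a 5.4-fold lower number from compound 3 to compound 4 (0.73 log units; beyond the scatter), a step the set could not show before. This position on the six-membered non-aromatic ring with 2 nitrogen is therefore not indifferent to what it carries, and here the group with more heavy atoms, a six-membered aromatic ring and a hydrogen-bond acceptor goes with less compound being tolerated. Nothing available bears on what lies behind this step.

From the compounds shown here alone, it remains open whether the lower number follows the ring nitrogen of pyridin-2-yl or the aromatic ring as such, a question that phenyl on the same amine nitrogen would address, while ethyl or benzyl there would show how the number moves with a chain or a ring held further out. Also open, going by these compounds, is whether the same change would give a step of similar size on the cores of compound 1 and compound 2.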